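The compounds below may be only part of what the source reports. "The series", "measured", "known", "first", "only" and "open" are said of these compounds alone.

Compound 1 `CN1CCC(CNS(=O)(=O)c2ccccc2Nc2cc(-c3ccc4ccn(C)c4c3)c3nccnc3c2)C1`: 11 nM
Compound 2 `CN1CCC(NS(=O)(=O)c2ccccc2Nc2cc(-c3ccc4ccn(C)c4c3)c3nccnc3c2)C1`: 33 nM
Compound 3 `CC(=O)N1CCC(NC(=O)c2ccncc2Nc2cc(-c3ccc4ccn(C)c4c3)c3nccnc3c2)CC1`: 18 nM

These three were tested in an assay for inhibition of 6-phosphofructo-2-kinase/fructose-2,6-bisphosphatase 3 (Homo sapiens), read by ADP-Glo, with a stated time of 2 h; a higher number here means a weaker inhibitor, a lower number a stronger inhibitor. Compound 3 stands second highest of the three numbers, within the scatter of both compound 1 and compound 2. Compound 4 `CC(=O)N1CCC(NC(=O)c2ccncc2Nc2cc(-c3ccc4ccn(C)c4c3)c3nccnc3c2)C1` is not yet measured; it differs from compound 3 in one place: 1-acetylpyrrolidin-3-yl in place of 1-acetylpiperidin-4-yl on an amide-type nitrogen. For the measured compounds named here, the only measured step that resembles this, a shortening of the group on a sulfonamide nitrogen, read a 3.0-fold higher number from compound 1 to compound 2 (0.48 log units; beyond the scatter). Going by the values given here, no step changes a ring size on an amide-type nitrogen, so the analogy is loose. A modest weakening, or no change beyond the scatter, is expected for compound 4 in this assay, a 1.7-fold higher number from compound 3 to compound 4 (0.22 log units; within the scatter). Compound 4 is estimated at 30 nM, with a range from 12 nM to 80 nM.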

Compound 4, half-maximal inhibitory concentration: 105 nM
Compound 4: the middle estimate sits 3.5-fold (0.54 log units) below what was measured; measured number above the stated range.
By their numbers in this assay, from the lowest: compounds 1, 3 and 2 (each within the scatter of the next, the first and the last beyond it); then compound 4.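

For the compounds shown here, on this amide-type nitrogen, replacing 1-acetylpiperidin-4-yl with 1-acetylpyrrolidin-3-yl gives a 5.8-fold higher number from compound 3 to compound 4 (0.77 log units; beyond the scatter), the first measured ring-size change at this place. The six-membered ring becomes five-membered, while the counts of hydrogen-bond donors and acceptors and the absence of net charge stay the same, yet the step lies beyond the scatter. No measurement here explains the loss.

Still open, as far as these compounds go, is whether a secondary amine in place of the acetyl group on the five-membered ring would give a different number. From the compounds shown here alone, whether the same ring change would have a similar effect on a sulfonamide nitrogen also remains open.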